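The source may hold more compounds than are shown below. What is called first, only, known or untested is meant among the compounds shown, and "the series" means these compounds.

Measured compounds:
compound 1 `N=C(N)c1ccc(-c2ccc(-c3cc(Cl)cc(Cl)c3)s2)s1` — 17%
compound 2 `N=C(N)c1ccc(-c2ccc(-c3ccccc3)s2)s1` — 85.1%
compound 3 `COc1cccc(-c2ccc(-c3ccc(C(=N)N)s3)s2)c1` — 79%

In an ADME assay on cells (Erythrocyte, Homo sapiens) for activation, read by hemolysis, with a stated time of 30 min, tested at 10 mM (on this read-out lower numbers stand for a weaker effect and higher numbers for a stronger effect at the one concentration tested), compound 2 stands highest of the three numbers; compound 3 is nearest, and compound 1 is the furthest, its number beyond the scatter lower. Compound 4 `N=C(N)c1ccc(-c2ccc(-c3ccc(F)cc3)s2)s1` is not yet measured. It differs from compound 2 in one place: fluoro in place of hydrogen on an aromatic carbon. Among the compounds with values here, the one measured step that bears on a single ring substitution here is a number 6.1 percentage points lower from compound 2 to compound 3 (within the scatter), and it lies within the scatter. The large gap to compound 1 involves two chloro groups, not one substituent, so it weighs less. On this basis a step of a number 10.1 percentage points lower from compound 2 to compound 4 (beyond the scatter) is expected, none beyond the scatter. Compound 4 is estimated at 75%, within 45% to 95%.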

Compound 4, a percentage reported as activity, at one concentration (the size of the read-out at that concentration, not a potency): 93.3%
Beside the measured number, compound 4's estimate is 18.3 percentage points below it, and the stated range covers the measured number.
By their numbers in this assay, from the lowest: compound 1; then compounds 3, 2 and 4 (each within the scatter of the next, the first and the last beyond it).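

In this assay, the first substituent shown para to a large group on the six-membered aromatic ring, fluoro in place of hydrogen, gives a number 8.2 percentage points higher from compound 2 to compound 4 (within the scatter). This position therefore accepts fluoro with no change that can be read beyond the scatter, and the methoxy step, a number 6.1 percentage points lower from compound 2 to compound 3 (within the scatter), is likewise within the scatter. The compounds shown offer no measured explanation for the fluoro result. Still open, on these data alone, is whether a single chloro, an amine or a carboxylic acid at this place would stay within the scatter of compound 2.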